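This account rests on a few compounds, and the source may have more. Where it says the series, first, only, none or still open, it means among the compounds named here.

Compound 1 `CC(=O)OC[C@H]1O[C@@H](n2cc(CN3C(=O)/C(=C/c4ccc(C)cc4)c4ccccc43)nn2)[C@H](OC(C)=O)[C@@H](OC(C)=O)[C@@H]1OC(C)=O` gives in a functional assay on MCF7 cells (Homo sapiens) for cytotoxicity, read by sulforhodamine B assay, with a stated time of 48 h (on this read-out higher numbers stand for weaker inhibition and lower numbers for stronger inhibition), a value that is only a limit of the assay, > 100000 nM.
Compound 2 `CC(=O)OC[C@H]1O[C@@H](n2cc(CN3C(=O)/C(=C/C=C/c4ccccc4)c4ccccc43)nn2)[C@H](OC(C)=O)[C@@H](OC(C)=O)[C@@H]1OC(C)=O` gives in this assay 53200 nM.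
Compound 3 `CC(=O)OC[C@H]1O[C@@H](n2cc(CN3C(=O)/C(=C/c4ccc5ccccc5c4)c4ccccc43)nn2)[C@H](OC(C)=O)[C@@H](OC(C)=O)[C@@H]1OC(C)=O` gives in this assay 32700 nM.

Of the two numbers shown, compound 3 and compound 2 lie close together, since a 1.6-fold lower number from compound 2 to compound 3 (0.21 log units; within the scatter); the value of compound 1 is a limit and gives no number to compare. Compound 4 `CCC/C=C1/C(=O)N(Cc2cn([C@@H]3O[C@H](COC(C)=O)[C@@H](OC(C)=O)[C@H](OC(C)=O)[C@H]3OC(C)=O)nn2)c2ccccc21` differs from compound 3 in one place: propyl in place of naphthalen-2-yl on a double-bonded chain carbon bound to a double-bonded ring carbon. The measured steps that bear on this place are an at least 3.0-fold lower number from compound 1 to compound 3 (0.48 log units; beyond the scatter) and an at least 1.8-fold lower number from compound 1 to compound 2 (0.27 log units; that floor lies within the scatter), both of which replaced the 4-methylphenyl group with a larger group and gave lower numbers, and a 1.6-fold lower number from compound 2 to compound 3 (0.21 log units; within the scatter), which stayed within the scatter. Among the compounds with values here, no measured step removes the ring at this place altogether. Compound 4 is therefore expected to give a higher number in this assay, with a 2.4-fold higher number from compound 3 to compound 4 (0.39 log units; beyond the scatter). The estimate for compound 4 in this assay is 80000 nM, with a range from 30000 nM to 200000 nM, and it may come out as a limit only.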

Compound 4, half-maximal inhibitory concentration: 22600 nM
Compound 4: the middle estimate sits 3.5-fold (0.55 log units) above what was measured; the whole stated range lies above it.
By their numbers in this assay, from the lowest: compounds 4, 3 and 2 (each within the scatter of the next, the first and the last beyond it). At a limit, above all of these: compound 1.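

In this assay, a ring is not required at this place, on a double-bonded chain carbon bound to a double-bonded ring carbon: propyl, which has no ring, stands level with naphthalen-2-yl, with a 1.4-fold lower number from compound 3 to compound 4 (0.16 log units; within the scatter). The earlier gain with larger groups therefore does not extend into a rule that larger is better, since compound 4 goes against it and carries the smallest group here, with a 2.4-fold lower number from compound 2 to compound 4 (0.37 log units; beyond the scatter). Compound 1 stands at a limit of the assay, so an at least 4.4-fold lower number from compound 1 to compound 4 (0.64 log units; beyond the scatter) is only a floor: the limit of > 100000 nM in this assay, at which 1 of the 4 values shown sits.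

As far as these compounds go, whether a longer chain, or a chain ending in an amine or a carboxylic acid, would shift the number further at this place remains open. So does whether the step to propyl holds on other cells.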